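Aminopiperidinyl replacing bromo in a sulfonyl acylguanidine

The source may hold more compounds than are shown below. What is called first, only, known or untested is meant among the compounds shown, and "the series" means these compounds.

Compound 3 `CS(=O)(=O)c1cc(C(=O)N=C(N)N)ccc1Br` gives 180 nM in a functional assay for inhibition of sodium/hydrogen exchanger (Oryctolagus cuniculus); on this read-out lower numbers stand for stronger inhibition and higher numbers for weaker inhibition. Compound 2 `CS(=O)(=O)c1cc(C(=O)N=C(N)N)ccc1C(F)(F)F` gives 140 nM and compound 1 `Cc1ccc(-c2ccc(C(=O)N=C(N)N)cc2S(C)(=O)=O)cc1` gives 100 nM; the steps of a 1.4-fold higher number from compound 1 to compound 2 (0.15 log units; within the scatter), a 1.8-fold higher number from compound 1 to compound 3 (0.26 log units; within the scatter) and a 1.3-fold higher number from compound 2 to compound 3 (0.11 log units; within the scatter) all lie within the scatter, so the three stand together. Compound 4 `CS(=O)(=O)c1cc(C(=O)N=C(N)N)ccc1N1CCC(N)CC1` differs from compound 3 by 4-aminopiperidin-1-yl in place of bromo on an aromatic carbon. For the measured compounds named here, the measured steps all exchange one substituent at this same position, and none moves the number beyond the scatter, which is the only guidance available; no step introduces a ring or a hydrogen-bond donor there. Compound 4 is therefore expected to give a number near that of compound 3, with the step of a 1.1-fold higher number from compound 3 to compound 4 (0.05 log units; within the scatter) estimated as small and its direction uncertain. The estimate for compound 4 is 200 nM, in the range 60 nM to 700 nM.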

Compound 4, half-maximal inhibitory concentration: 160 nM
Estimate against measurement, compound 4: 1.3-fold (0.10 log units) above; measured number inside the range.
By their numbers in this assay, from the lowest: compounds 1, 2, 4 and 3 (each within the scatter of the next).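

In this assay the steps of a 1.1-fold lower number from compound 3 to compound 4 (0.05 log units; within the scatter) and a 1.1-fold higher number from compound 2 to compound 4 (0.06 log units; within the scatter) and a 1.6-fold higher number from compound 1 to compound 4 (0.20 log units; within the scatter) all lie within the scatter. The position on an aromatic carbon ortho to a methylsulfonyl group therefore accepts 4-aminopiperidin-1-yl, with its six-membered non-aromatic ring and hydrogen-bond donor, and compound 4 stands together with the bromo, trifluoromethyl and 4-methylphenyl compounds. Nothing available accounts for this result. The compounds shown leave open whether the amine of the piperidine matters, which plain piperidin-1-yl would test. They also leave open whether a carboxylic acid or a longer chain ending in an amine would move the number beyond the scatter.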